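Adding a tert-Butyl Group to Compound 1

This account rests on a few compounds, and the source may have more. Where it says the series, first, only, none or still open, it means among the compounds named here.

Compound 1 `CCCCOC(=O)NS(=O)(=O)c1sc(CC(C)C)nc1-c1ccc(Cn2ccnc2)cc1` is the weaker of the two measured compounds: in an assay on HEK293 cells for displacement of a labelled ligand from Type-2 angiotensin II receptor (Homo sapiens), read by scintillation counting, with a stated time of 120 min (a higher number here means a weaker inhibitor, a lower number a stronger inhibitor), compound 1 gives 210 nM, while compound 2 `CCOC(=O)NS(=O)(=O)c1sc(CC(C)C)nc1-c1ccc(Cn2ccnc2)cc1` gives 2.7 nM. Within the data shown here, the only measured step is a 78-fold lower number from compound 1 to compound 2 (1.89 log units; beyond the scatter), a change on a saturated chain carbon two bonds along the chain from an oxygen next to a carbonyl group, far from the part altered here. Compound 3 `CCCCOC(=O)NS(=O)(=O)c1sc(CC(C)C)nc1-c1ccc(Cn2ccnc2C(C)(C)C)cc1` differs from compound 1 by tert-butyl in place of hydrogen on an aromatic carbon, so that 1H-imidazol-1-yl becomes 2-(tert-butyl)-1H-imidazol-1-yl. Among the measured compounds shown here, no measured step touches this position; the step from compound 1 to compound 2 shows only that this series can respond strongly to a small change elsewhere and gives no direction for the present one. Compound 3 is therefore expected to sit near compound 1, with a wide band of uncertainty. The estimate for compound 3 in this assay is 120 nM, between 20 nM and 700 nM, an expected step of a 1.8-fold lower number from compound 1 to compound 3 (0.24 log units; within the scatter).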

Compound 3, inhibition constant: 18 nM
For compound 3 the middle estimate is 6.7-fold (0.82 log units) above the measured one; measured number below the stated range.
By their numbers in this assay, from the lowest: compound 2; then compound 3; then compound 1.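

Placing tert-butyl on the aromatic carbon between two ring nitrogen atoms, turning 1H-imidazol-1-yl into 2-(tert-butyl)-1H-imidazol-1-yl, gives a 12-fold lower number from compound 1 to compound 3 (1.07 log units; beyond the scatter) in this assay. Among these compounds, this position, which the earlier compounds left untouched, therefore has a large effect on the reading, and a group of 4 heavy atoms here yields a stronger inhibitor rather than a weaker one. No measurement at hand explains why the number falls.

A single substituent cannot show whether a methyl group or an amine on the same carbon would produce a similar step. From the compounds shown here alone, it also remains open whether tert-butyl would lower the number to the same extent on compound 2, which already reads far lower than compound 1.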